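The source may hold more compounds than are shown below. What is called first, only, known or untested is meant among the compounds shown, and "the series" means these compounds.

Series notes, measured in a functional assay on HCT-116 cells (Homo sapiens) for cytotoxicity, read by MTT assay, with a stated time of 72 h; a higher number here means a weaker inhibitor, a lower number a stronger inhibitor:

- compound 1 `COc1cccc(CNC(=O)c2nc(Br)c3cccnc3c2N[C@H]2CC[C@H](N)CC2)c1`: 6000 nM
- compound 2 `N[C@H]1CC[C@H](Nc2c(C(=O)NCc3ccc(F)cc3)nc(N3CCCCC3)c3cccnc23)CC1`: 8000 nM

Compound 1 at 6000 nM and compound 2 at 8000 nM lie within the scatter of each other, so the two numbers cannot be told apart and compound 1 has no meaningful rank in this small set. For the measured compounds named here, no two measured compounds differ in one place only, so the series offers no measured step to carry across.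

Next in line is compound 3 `N[C@H]1CC[C@H](Nc2c(C(=O)NCc3ccc(Cl)cc3)nc(Br)c3cccnc23)CC1`, which keeps the core of compound 1 and changes one group: 4-chlorophenyl in place of 3-methoxyphenyl on a saturated chain carbon bound to an amide-type nitrogen. In plain terms, 4-chlorophenyl stands in place of 3-methoxyphenyl on a saturated chain carbon bound to an amide-type nitrogen.

Going by the values given here, with no measured step as a guide, the working expectation rests on compound 1 at 6000 nM as the starting point, and no shift beyond the scatter is expected in either direction. The expected change is a 1.2-fold lower number from compound 1 to compound 3 (0.08 log units; within the scatter). In this assay the estimate for compound 3 is 5000 nM, with an expected range of 1800 nM to 14000 nM.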

Compound 3, half-maximal inhibitory concentration: 4000 nM
Beside the measured number, compound 3's estimate is 1.3-fold (0.10 log units) above it; the measured number falls inside the stated range.
By their numbers in this assay, from the lowest: compounds 3, 1 and 2 (each within the scatter of the next).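

For the compounds shown here, the only one-place comparison so far reads, in this assay, as a 1.5-fold lower number from compound 1 to compound 3 (0.18 log units; within the scatter) and so gives no sign that 3-methoxyphenyl and 4-chlorophenyl can be told apart on a saturated chain carbon bound to an amide-type nitrogen. Going by these compounds alone, what compound 3 adds is that this position keeps its number within the scatter when the ring substituent and its ring position both change, from 3-methoxybenzyl to 4-chlorobenzyl, although the one step cannot separate the contribution of the substituent from that of its position. No evidence on the cause of this result is available.

From the compounds shown here alone, the matched forms that would separate those two contributions, 4-methoxybenzyl and 3-chlorobenzyl, remain open, as does the question of whether a different group on the amide nitrogen, such as unsubstituted benzyl, phenethyl or cyclohexylmethyl, or a carboxylic acid or an amine on the phenyl ring, would take the number beyond the scatter. Also open, going by these compounds, is what piperidine does in place of bromine with the rest of the structure held fixed, since compound 2 differs from compound 1 and from compound 3 in more than one place.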